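Replacing the acetyl group of compound 2

A few compounds are considered here, and "the series" means these few. Any claim that something is new, unique, unknown or untested is made for them only; others in the source may bear on it.

Results so far in an ADME assay on BHK-21 cells (Mesocricetus auratus) for cytotoxicity, read by MTT assay (a lower number here means that less compound is tolerated, a higher number that more compound is tolerated), are these:
compound 1 `C/C(=N\NC(N)=S)c1ccc2[nH]c(-c3ccccc3)nc2c1` gives 32000 nM
compound 2 `CC(=O)c1ccc2[nH]c(-c3ccoc3)nc2c1` gives 98000 nM

Compound 2 holds the higher of the two numbers, so more of it is tolerated, and its gap to compound 1 lies beyond the usual scatter. Compound 3 `C/C(=N\NC(N)=S)c1ccc2[nH]c(-c3ccoc3)nc2c1` differs from compound 2 in one place, with a group of 7 heavy atoms (3 carbon, 3 nitrogen, 1 sulfur; no ring) in place of a group of 3 heavy atoms (2 carbon, 1 oxygen; no ring), on an aromatic carbon on an aromatic carbon of the shared core. Among the compounds with values here, no measured pair shows this change alone. Compound 1 carries the same entering group and gives 32000 nM as its value, though it also differs from compound 2 elsewhere. The expected step is a 2.8-fold lower number from compound 2 to compound 3 (0.45 log units; beyond the scatter) in this assay and would lie beyond the scatter, toward less compound tolerated. The estimated value for compound 3 is 35000 nM (expected range 13000 nM to 95000 nM).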

Compound 3, half-maximal cytotoxic concentration: > 100000 nM
Compound 3: no number, only a limit; the forecaster's own chance of this, stated with the estimate: 10%; middle value at least 2.8-fold (0.45 log units) from the limit.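

In this assay compound 3 gives > 100000 nM, which is a limit of the assay and not a number. On this aromatic carbon, trading the acetyl group for the longer nitrogen- and sulfur-bearing chain does not bring the drop in tolerated compound that compound 1 had hinted at: the printed step is an at least 1.0-fold higher number from compound 2 to compound 3 (0.00 log units; that floor lies within the scatter), and that floor alone cannot size the change. Within the data shown here, with this chain held constant, swapping phenyl for furan-3-yl gives an at least 3.1-fold higher number from compound 1 to compound 3 (0.49 log units; beyond the scatter), so the ring on the far side of the shared core matters here, a change no earlier pair showed alone.

On these data alone, the true value of compound 3 stays unknown, so the size of both steps remains open. Also open, as far as these compounds go, are how an amine or a carboxylic acid on this aromatic carbon would read, and whether the phenyl ring makes the same difference when the acetyl group is present.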